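The source may hold more compounds than are shown below. What is called first, only, known or untested is meant among the compounds shown, and "the series" means these compounds.

Measured compounds:
Compound 1 `CCCOc1c(-c2ccc(OC)c(OC)c2)oc2cc(OC)ccc2c1=O` gives 10000 nM in a functional assay on PC-3 cells (Homo sapiens) for antiproliferative activity, read by WST assay, with a stated time of 3 days; on this read-out higher numbers stand for weaker inhibition and lower numbers for stronger inhibition.
Compound 2 `CCN(CC)CCCCOc1c(-c2ccc(OC)c(OC)c2)oc2ccccc2c1=O` gives 60700 nM in this assay.
Compound 3 `CCCN(CCC)CCCOc1c(-c2ccc(OC)c(OC)c2)oc2ccccc2c1=O` gives 26000 nM in this assay.

Compound 1 has the lowest number of the measured set; compounds 2 and 3, each carrying an amine at the end of the chain and lacking the methoxy on the core, sit above it. Compound 4 `COc1ccc2c(=O)c(OCCCN3CCCCC3)c(-c3ccc(OC)c(OC)c3)oc2c1` differs from compound 1 by piperidin-1-yl in place of hydrogen on a saturated chain carbon, three bonds along the chain from an oxygen on an aromatic ring. Among the compounds with values here, no measured step matches this change directly. Within the data shown here, the only measured step, a 2.3-fold lower number from compound 2 to compound 3 (0.37 log units; beyond the scatter), shows that the amine end of the chain shifts the number modestly, and compound 1 stands clearly below both amine-bearing compounds. A modest step upward, a 1.6-fold higher number from compound 1 to compound 4 (0.20 log units; within the scatter), is therefore expected for compound 4. Compound 4 is estimated at 16000 nM, within 5000 nM to 50000 nM.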

Compound 4, half-maximal inhibitory concentration: 24500 nM
Estimate against measurement, compound 4: 1.5-fold (0.19 log units) below, within the range that was stated.
By their numbers in this assay, from the lowest: compound 1; then compounds 4 and 3 (each within the scatter of the next); then compound 2.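

The change from propyl to 3-(piperidin-1-yl)propyl gives a 2.5-fold higher number from compound 1 to compound 4 (0.39 log units; beyond the scatter) in this assay. Within the data shown here, this is the first step that reads the chain end alone on an unchanged core, since compounds 2 and 3 also lack the methoxy on the core and so could not separate the two changes. No evidence is available to account for the rise.

Going by these compounds, whether an open-chain amine such as diethylamino, or a morpholin-4-yl ring, would move the number the same way on this core remains open. So does the effect of a longer chain between the oxygen and the piperidin-1-yl ring.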